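Hydrazone aryl swap on a shared urea core

This account rests on a few compounds, and the source may have more. Where it says the series, first, only, none or still open, it means among the compounds named here.

Compound 1 `CN(C)CCn1cnnc1-c1cc(Oc2ccc(NC(=O)N/N=C/c3cc(C(C)(C)C)cc(C(C)(C)C)c3O)cc2F)ccn1`: 520 nM
Compound 2 `COc1cc(/C=N/NC(=O)Nc2ccc(Oc3ccnc(-c4nncn4CCN(C)C)c3)c(F)c2)cc(OC)c1OC`: 22500 nM
Compound 3 `Cn1cnnc1-c1cc(Oc2ccc(NC(=O)N/N=C/c3ccccc3)cc2F)ccn1`: 36300 nM

The three compounds above share a urea core and were all tested in a functional assay on U-87MG ATCC cells (Homo sapiens) for cytotoxicity, read by MTT assay, with a stated time of 72 h (a higher number here means a weaker inhibitor, a lower number a stronger inhibitor), which gives the half-maximal inhibitory concentration. Compound 1 gives 520 nM in this assay, the lowest of the three numbers. Compound 2 gives 22500 nM, the second highest; its nearest neighbour is compound 3 at 36300 nM, a gap within the usual scatter, so no order between compound 2 and compound 3 can be read. Compound 1 stands far below compound 2, beyond the scatter.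

Compound 4 `CN(C)CCn1cnnc1-c1cc(Oc2ccc(NC(=O)N/N=C/c3cccc(O)c3)cc2F)ccn1` has not yet been measured in this assay. It differs from compound 2 by 3-hydroxyphenyl in place of 3,4,5-trimethoxyphenyl on a carbon with a double bond to nitrogen. Among the measured compounds shown here, no measured pair shows this change, so any expectation rests on the values of compound 2 and compound 3 alone. Compound 4 is expected to give 15000 nM, between 4000 nM and 50000 nM, and the step of a 1.5-fold lower number from compound 2 to compound 4 (0.18 log units; within the scatter) is estimated to lie within or near the scatter, a somewhat lower number being the more likely direction.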

Compound 4, half-maximal inhibitory concentration: > 100000 nM
Compound 4: only a limit was reported; the forecaster's own chance of this, stated with the estimate: 10%; at least 6.6-fold (0.82 log units) between middle value and limit.
By their numbers in this assay, from the lowest: compound 1; then compounds 2 and 3 (each within the scatter of the next). At a limit, above all of these: compound 4.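

Among the compounds shown here, exchanging 3,4,5-trimethoxyphenyl for 3-hydroxyphenyl on a carbon with a double bond to nitrogen gives an at least 4.4-fold higher number from compound 2 to compound 4 (0.64 log units; beyond the scatter) in this assay, the first single-place comparison here, and it shows that the number at this position depends on the aryl group it carries. A hydroxyl on the aryl group does not by itself set the number, since compound 1 gives 520 nM and also carries one. The value of compound 4 is a limit and not a number, so the step gives only a lower bound on the change: the limit of > 100000 nM in this assay, at which 1 of the 4 values shown sits.

A 3-methoxyphenyl or a 3-aminophenyl on this same core would help separate the loss of the methoxy groups from the arrival of the hydroxyl. On these data alone, how far compound 4 lies past its limit also stays open.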